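Methyl on the weak end of the series

The source may hold more compounds than are shown below. What is called first, only, known or untested is meant among the compounds shown, and "the series" means these compounds.

Measured in a functional assay on A549 cells (Homo sapiens) for inhibition, read by sulforhodamine B assay, with a stated time of 48 h; a lower number here means a stronger inhibitor, a higher number a weaker inhibitor:
- Compound 1 `CCO[C@H]1C[C@@H](c2coc3ccccc3c2=O)N(c2ccccc2)O1`: > 60000 nM (a limit)
- Compound 2 `O=c1c([C@@H]2C[C@H](c3ccccc3)ON2c2ccccc2)coc2ccc(Br)cc12`: 51000 nM
- Compound 3 `O=c1c([C@@H]2C[C@H](c3ccccc3)ON2c2ccccc2)coc2ccccc12`: > 60000 nM (a limit)

Compound 3 gives no number, only a limit: it stands at the limit of > 60000 nM in this assay, at which 2 of the 3 values shown sit. Compound 4 `Cc1ccc2occ([C@@H]3C[C@H](c4ccccc4)ON3c3ccccc3)c(=O)c2c1` carries methyl in place of hydrogen on an aromatic carbon, (methyl in place of hydrogen on an aromatic carbon). The measured exchange on an aromatic carbon is an at least 1.1-fold higher number from compound 2 to compound 3 (0.07 log units; that floor lies within the scatter), with hydrogen in place of bromo. The other measured exchange, on a saturated ring carbon, is a step that the two limits leave unreadable from compound 1 to compound 3, and offers no guide. On this evidence, no step beyond the scatter is expected in this assay, and another limit is quite possible. The expected change is a number no higher from compound 3 to compound 4 (the limit leaves the size open). Compound 4 is estimated at 60000 nM, with an expected range of 30000 nM to 120000 nM.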

Compound 4, half-maximal inhibitory concentration: 49000 nM
The estimate for compound 4 lay 1.2-fold (0.09 log units) above the measured number; low and high end bracket the measured number.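

In this assay, compound 4 gives a number where compound 3 gives only a limit, so methyl on this aromatic carbon, like bromo in compound 2, reads on the scale. The exchange of hydrogen for methyl is an at least 1.2-fold lower number from compound 3 to compound 4 (0.08 log units; that floor lies within the scatter), so it shows no step beyond the scatter. Methyl and bromo cannot be told apart on this carbon: the exchange is a 1.0-fold lower number from compound 2 to compound 4 (0.02 log units; within the scatter).

On these data alone, whether any group on this carbon moves the series off its weak end stays open. An amine, a carboxylic acid or a longer chain here could test that.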